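The source may report more compounds than this note shows. Statements on the series, on what has been measured and on what is new or still open speak of the compounds shown alone.

Compound 1 `CNC(=O)c1cccc2nc(-c3c[nH]c4c(C)cccc34)ccc12`: 0.983 h
Compound 2 `Cc1cccc2c(-c3ccc4c(F)cccc4n3)c[nH]c12`: 0.217 h

In an ADME assay on microsomes from liver (Homo sapiens) for metabolic stability, using NADPH, with a stated time of 40 min, tested at 2 uM (on this read-out higher numbers stand for a longer-lived compound and lower numbers for a shorter-lived compound), compound 2 has the lower of the two numbers, at 0.217 h. Compound 3 `Cc1cccc2c(-c3ccc4c(C(F)(F)F)cccc4n3)c[nH]c12` keeps the shared core and changes one group: trifluoromethyl in place of fluoro on an aromatic carbon. Going by the values given here, the only measured step, a 4.5-fold lower number from compound 1 to compound 2 (0.66 log units; beyond the scatter), lies beyond the scatter, but it describes fluoro in place of methylcarbamoyl. Among the compounds with values here, it shows that a change on this carbon can move the half-life, yet it does not compare fluoro with trifluoromethyl, and no measured pair does. With no direct evidence for a shift either way, no step beyond the scatter is expected. The estimated move is a 1.2-fold higher number from compound 2 to compound 3 (0.06 log units; within the scatter), and the wide range reflects how little is known. For compound 3 the expected half-life is 0.25 h, with an estimated range from 0.1 h to 0.6 h.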

Compound 3, half-life: 1.25 h
Compound 3: middle estimate off by 5.0-fold (0.70 log units), on the low side; the whole stated range lies below it.
By their numbers in this assay, from the lowest: compound 2; then compounds 1 and 3 (each within the scatter of the next).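

In this assay, putting trifluoromethyl in place of fluoro on this aromatic carbon gives a 5.8-fold higher number from compound 2 to compound 3 (0.76 log units; beyond the scatter), so losing methylcarbamoyl does not by itself bring the short half-life of compound 2. Trifluoromethyl and methylcarbamoyl cannot be told apart here, as the comparison gives a 1.3-fold higher number from compound 1 to compound 3 (0.10 log units; within the scatter), which lies within the usual scatter of this kind of measurement. Nothing available explains why fluoro and trifluoromethyl behave so differently at this carbon.

As far as these compounds go, three groups on one carbon are too few to show a trend, so it remains open how a chloro group, a nitrile or an amine would fare there. From the compounds shown here alone, it is also open whether trifluoromethyl in place of fluoro would have a similar effect on another carbon of the shared core.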